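A few compounds are considered here, and "the series" means these few. Any claim that something is new, unique, unknown or untested is made for them only; others in the source may bear on it.

Measured compounds:
compound 2 `CN1CCN(c2nc(-c3ccc(Cl)c(Cl)c3)nc3[nH]cnc23)CC1` — > 80%
compound 3 `CN1CCN(c2nc(-c3ccc(Cl)c(C(F)(F)F)c3)nc3[nH]cnc23)CC1` — > 80%
compound 1 `Cn1cnc2c(N3CCCCC3)nc(-c3ccccc3O)nc21` — 20%

In an assay on cells for displacement of a labelled ligand from adenosine receptor A3 (Homo sapiens), read by scintillation counting and radioligand binding, with a stated time of 180 min, tested at 10 uM (a higher number here means more inhibition at the concentration tested (going by the name of the read-out), a lower number less inhibition), compound 2 gives > 80%, which is a limit of the assay and not a number. Compound 3 likewise gives > 80%, again a limit. Compound 1, built on a different core with a piperidine and a hydroxyphenyl, gives 20%. Because of the limit of > 80% in this assay, at which 2 of the 3 values shown sit, the step that the two limits leave unreadable from compound 2 to compound 3 cannot be read, so the measured compounds yield no readable step at all.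

Compound 4 `CN1CCN(c2nc(-c3cccc(Cl)c3)nc3[nH]cnc23)CC1` differs from compound 2 in one place: hydrogen in place of chloro on an aromatic carbon. For the measured compounds named here, no measured step bears directly on this change. Compound 1 differs from compound 2 in several places at once, so its lower value shows only that another combination gives less. With compound 2 standing at a limit, the step to compound 4 is therefore unreadable in direction and size from the data, and a moderate fall is merely expected from removing one chloro.

Compound 4 is expected to give 62% in this assay, within 35% to 85%. The step of a number at least 18 percentage points lower from compound 2 to compound 4 (beyond the scatter) is thus estimated as a moderate decrease.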

Compound 4, a percentage reported as inhibition, at one concentration (the size of the read-out at that concentration, not a potency): > 80%
Compound 4: only a limit was reported; the forecaster's own chance of this, stated with the estimate: 30%; middle value at least 18 percentage points away from the limit.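

No new step can be read between compound 2 and compound 4, because both sit at the same limit of the assay rather than at a number: the limit of > 80% in this assay, at which 3 of the 4 values shown sit.

The compounds shown leave open whether going from 3,4-dichlorophenyl to 3-chlorophenyl changes the inhibition in this assay at all.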